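A few compounds are considered here, and "the series" means these few. Any claim that something is new, unique, unknown or untested is made for them only; others in the source may bear on it.

Working notes on the series.

Compound 1 `COc1ccc(-c2csc(N)c2C(=O)OCc2ccc(F)cc2)cc1OC` and compound 2 `COc1ccc(-c2csc(N)c2C(=O)OCc2ccc(C#N)cc2)cc1OC` share a core, and compound 3 `Nc1scc(-c2cccc(F)c2)c1C(=O)OCc1ccccc1` is built on a core that differs from that of compound 1 in more than one place; the difference between the two cores is not broken down here. In an assay on isolated protein for inhibition of protein kinase C zeta type (Homo sapiens), with stated times of 1 h and 2.5 min, tested at 30 uM (on this read-out higher numbers stand for more inhibition at the one concentration tested (going by the name of the read-out) and lower numbers for less inhibition), compound 1 gives 2%. Compound 2 gives 10%, so that a number 8 percentage points higher from compound 1 to compound 2 (within the scatter), the change being (cyano in place of fluoro on an aromatic carbon). Compound 3 gives 53%, the highest of the three numbers, with its gaps to compound 2 and to compound 1 both beyond the scatter.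

Compound 4 `N#Cc1cccc(-c2csc(N)c2C(=O)OCc2ccccc2)c1` is not yet measured. It relates to compound 3 by cyano in place of fluoro on an aromatic carbon. This is the same kind of change as from compound 1 to compound 2, but not the same: there the entering group sits para to a large group, here it sits meta to a large group, and the two cores differ as noted. Among the compounds with values here, the only measured precedent is within the scatter, so for compound 4 the step is expected to be small, a number 2 percentage points higher from compound 3 to compound 4 (within the scatter), because the earlier change gave a number 8 percentage points higher from compound 1 to compound 2 (within the scatter). Compound 4 is estimated at 55% in this assay, with a likely range from 35% to 75%.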

Compound 4, a percentage reported as inhibition, at one concentration (the size of the read-out at that concentration, not a potency): 25%
Estimate against measurement, compound 4: 30 percentage points above; measured number below the stated range.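

In this assay, cyano in place of fluoro does not carry over as one fixed step from one core to the other: the same change on two cores in this assay, a number 8 percentage points higher (within the scatter) from compound 1 to compound 2 and a number 28 percentage points lower (beyond the scatter) from compound 3 to compound 4, 36 percentage points apart, beyond the scatter of two such steps On the core of compound 3, where the change reads as 3-fluorophenyl to 3-cyanophenyl, the result is a number 28 percentage points lower from compound 3 to compound 4 (beyond the scatter), so the small step seen on the core of compound 1 gives no safe guide to the size or direction of the step on the core of compound 3. This does not show which difference between the two pairs matters, since the cores differ in more than one place and the entering group also sits in a different place on its aromatic ring, and two pairs cannot separate these differences or support a general rule for the series.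

The compounds shown leave open how other groups would read in this assay in place of the fluoro of compound 3, such as chloro, methyl, an amine or a carboxylic acid. They also leave open whether the same cyano for fluoro change would behave as it does from compound 3 to compound 4 if only the ring placement were altered, with the core held constant.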